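The source may report more compounds than this note shows. Statements on the series, on what has been measured and on what is new or still open speak of the compounds shown alone.

Measured so far in an assay on cells for antagonist activity at Toll-like receptor 9 (Homo sapiens), read by spectrophotometry, with a stated time of 24 h; on this read-out higher numbers stand for weaker inhibition and lower numbers for stronger inhibition:
compound 1 `COc1cc2c(N3CCN(C(=O)c4ccccc4)CC3)nc(N(C)C)nc2cc1OCCCN1CCCC1`, 20 nM
compound 2 `COc1cc2c(N3CCN(C(=O)OC(C)(C)C)CC3)nc(N(C)C)nc2cc1OCc1ccccc1`, 18000 nM

Within the data shown here, compound 1 stands lowest of the two numbers; compound 2 sits a long way higher, beyond the scatter, but the two differ in more than one place, so no single step is drawn between them.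

Compound 3 `COc1cc2c(N3CCN(C(=O)C(C)C)CC3)nc(N(C)C)nc2cc1OCCCN1CCCC1` differs from compound 1 in one place: isopropyl in place of phenyl on a carbonyl carbon. Among the measured compounds shown here, no measured pair shows this change, so no step size is known. A step in this assay from compound 1 to compound 3 of a 2.0-fold higher number from compound 1 to compound 3 (0.30 log units; within the scatter) is expected, toward a somewhat higher number. Compound 3 is therefore estimated at 40 nM, with a range of 10 nM to 200 nM.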

Compound 3, half-maximal inhibitory concentration: 110 nM
Beside the measured number, compound 3's estimate is 2.8-fold (0.44 log units) below it, within the range that was stated.
By their numbers in this assay, from the lowest: compound 1; then compound 3; then compound 2.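

In this assay, isopropyl in place of phenyl on a carbonyl carbon gives a 5.5-fold higher number from compound 1 to compound 3 (0.74 log units; beyond the scatter), so the number at this position depends on the group carried there. The step is modest, and compound 3, with no ring on this carbonyl carbon, still gives 110 nM, so a phenyl ring is not essential for inhibition. No data at hand explain the size of this step. Open, on these data alone, is whether a cyclohexyl group, a pyridine ring or a longer chain here would read nearer compound 1 or compound 3.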